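Amide variation on a shared core: notes toward compound 4

The compounds below may be only part of what the source reports. "The series", "measured", "known", "first", "only" and "open" are said of these compounds alone.

All numbers below come from an assay (strain Wistar) for displacement of a labelled ligand from adenosine receptor A1 (Rattus norvegicus), read by scintillation counting; a lower number here means a stronger inhibitor, a higher number a weaker inhibitor.

compound 1 `O=C(Nc1nc(-c2ccccc2)nc2c1nnn2Cc1ccccc1)c1cccc(F)c1` — 22 nM
compound 2 `Nc1nc(-c2ccccc2)nc2c1nnn2Cc1ccccc1` — 5.6 nM
compound 3 `O=C(Nc1nc(-c2ccccc2)nc2c1nnn2Cc1ccccc1)C1CC1` — 7.5 nM

Compound 3 stands second highest of the three numbers. Its nearer neighbour is reached by a step within the scatter: a 1.3-fold higher number from compound 2 to compound 3 (0.13 log units; within the scatter). Its further neighbour lies beyond the scatter: a 2.9-fold lower number from compound 1 to compound 3 (0.47 log units; beyond the scatter). The one aryl amide in the set, compound 1, is thus the weakest of the three in this assay, and the free amine and the cyclopropyl amide sit together.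

The next compound is compound 4 `O=C(Nc1nc(-c2ccccc2)nc2c1nnn2Cc1ccccc1)c1cccc(C(F)(F)F)c1`. Relative to compound 3 the change is 3-(trifluoromethyl)phenyl in place of cyclopropyl on a carbonyl carbon.

The step that bears on this is a 2.9-fold lower number from compound 1 to compound 3 (0.47 log units; beyond the scatter), read in reverse: putting an aryl group on the carbonyl carbon where the cyclopropyl sat gave a higher number. The step of a 3.9-fold lower number from compound 1 to compound 2 (0.59 log units; beyond the scatter) points the same way, the aryl amide again above the unsubstituted amine. Within the data shown here, no measured step tells how a trifluoromethyl on the ring compares with a fluorine there, so the expectation rests on the aryl-for-cyclopropyl exchange alone. A modest rise is therefore expected: a 3.3-fold higher number from compound 3 to compound 4 (0.52 log units; beyond the scatter). For compound 4 the estimate is 25 nM, with a range of 8 nM to 80 nM.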

Compound 4, inhibition constant: 163 nM
For compound 4 the middle estimate is 6.5-fold (0.81 log units) below the measured one; the whole stated range lies below it.
By their numbers in this assay, from the lowest: compounds 2 and 3 (each within the scatter of the next); then compound 1; then compound 4.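

On the carbonyl carbon in this assay, 3-(trifluoromethyl)phenyl in place of cyclopropyl gives a large step, a 22-fold higher number from compound 3 to compound 4 (1.34 log units; beyond the scatter), so the exchange of cyclopropyl for an aryl group does not carry one fixed cost in this series. The substituent on the aromatic ring matters as well: trifluoromethyl in place of fluoro on an aromatic carbon gives a 7.4-fold higher number from compound 1 to compound 4 (0.87 log units; beyond the scatter), a step beyond the scatter with the rest of the amide unchanged. The two aryl amides therefore do not sit together, and compound 4 has the highest number of the four. No measurement offered here accounts for the size of either step.

From the compounds shown here alone, with only fluoro and trifluoromethyl on the ring, it remains open whether the number rises steadily with the substituent or whether these two points are specific to these groups; a methoxy, a chlorine or a nitrile in that place would help to decide this. Also open is how an unsubstituted phenyl, or a longer chain such as butyl in place of cyclopropyl on the carbonyl carbon, would compare with the amides shown.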